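From compound 1 to compound 3: one group removed

The source may hold more compounds than are shown below. What is called first, only, known or untested is meant among the compounds shown, and "the series" means these compounds.

Measured so far in a functional assay on MM1.S cells (Homo sapiens) for antiproliferative activity, read by resazurin assay, with a stated time of 69 h; on this read-out higher numbers stand for an effect only at larger amounts of compound and lower numbers for an effect already at smaller amounts
- Compound 1 `Cc1cc(C)cc(Oc2cccc(-c3c(C)nnn3C3CCN(C(=N)N)CC3)n2)c1` gives > 50000 nM (a limit of the assay)
- Compound 2 `Cc1cc(C)cc(Oc2nccc(-c3c(C)nnn3C3CCNCC3)n2)c1` gives 6600 nM (a measured number)

Compound 1 stands at the limit of > 50000 nM in this assay, at which 1 of the 2 values shown sits, and this is a limit, not a number. The change to compound 3 `Cc1cc(C)cc(Oc2cccc(-c3c(C)nnn3C3CCNCC3)n2)c1`, not yet measured, is this: a hydrogen atom in place of a group of 3 heavy atoms (1 carbon, 2 nitrogen; no ring), on an amine nitrogen in a ring (a hydrogen atom in place of a group of 3 heavy atoms, on an amine nitrogen in a ring). Among the measured compounds shown here, no measured step shows what such a change does, so the expectation leans on compound 2 at 6600 nM as the only real number. A clear move to lower numbers is expected, with an estimated at least 10-fold lower number from compound 1 to compound 3 (1.00 log units; beyond the scatter) in this assay as its size. For compound 3 the estimated value is 5000 nM with an expected range from 1500 nM to 20000 nM (an estimate only).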

Compound 3, half-maximal effective concentration: 2900 nM
Beside the measured number, compound 3's estimate is 1.7-fold (0.24 log units) above it; the measured number falls inside the stated range.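

Replacing the group of 3 heavy atoms on the amine nitrogen in the ring with a hydrogen atom gives an at least 17-fold lower number from compound 1 to compound 3 (1.23 log units; beyond the scatter) in this assay. Among the compounds shown here, this is the first single-place comparison, and it shows that the effect in cells depends strongly on what this nitrogen carries. The step has only a minimum size and no exact one, because one of its ends is a limit: the limit of > 50000 nM in this assay, at which 1 of the 3 values shown sits.

Only hydrogen and this one group are shown at this position. As far as these compounds go, how a methyl or an acetyl group on the same nitrogen would fare remains open.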